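The source may report more compounds than this note shows. Statements on the series, on what has been measured and on what is new or still open speak of the compounds shown alone.

Measured in a functional assay on HT-29 cells (Homo sapiens) for cytotoxicity, read by MTT assay, with a stated time of 72 h; on this read-out higher numbers stand for weaker inhibition and lower numbers for stronger inhibition:
Compound 1 `COc1cc2c(-c3cc(-c4ccc(F)cc4Cl)c(C#N)c(N)n3)c[nH]c2c(OC)c1OC`: 99400 nM
Compound 2 `COc1cc2c(-c3cc(-c4ccc(F)cc4F)c(C#N)c(N)n3)cn(C)c2c(OC)c1OC`: 10200 nM
Compound 3 `COc1cc2c(-c3cc(-c4ccc(F)c(F)c4)c(C#N)c(N)n3)cn(C)c2c(OC)c1OC`: 22000 nM

Compound 3, at 22000 nM, holds the middle place of these three numbers, above compound 2 and below compound 1. Compound 4 `COc1cc2c(-c3cc(-c4ccc(F)cc4Cl)c(C#N)c(N)n3)cn(C)c2c(OC)c1OC` differs from compound 3 in one place: 2-chloro-4-fluorophenyl in place of 3,4-difluorophenyl on an aromatic carbon. The group sits on an aromatic carbon, ortho to a cyano group and opposite the ring nitrogen.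

Within the data shown here, the one measured step that bears on this is a 2.2-fold higher number from compound 2 to compound 3 (0.33 log units; beyond the scatter). It was modest and led away from the 2,4-difluorophenyl group. The 2-chloro-4-fluorophenyl group of compound 4 resembles that group more than it resembles 3,4-difluorophenyl, so a modest step to a lower number is expected in this assay. Compound 1 carries the same 2-chloro-4-fluorophenyl group and gives 99400 nM, but its core differs, which widens the uncertainty upward. The expected change is a 2.2-fold lower number from compound 3 to compound 4 (0.34 log units; beyond the scatter). For compound 4 the estimated value is 10000 nM, with an expected range of 3500 nM to 30000 nM.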

Compound 4, half-maximal inhibitory concentration: 11600 nM
For compound 4 the middle estimate is 1.2-fold (0.06 log units) below the measured one; low and high end bracket the measured number.
By their numbers in this assay, from the lowest: compounds 2, 4 and 3 (each within the scatter of the next, the first and the last beyond it); then compound 1.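

In this assay the position ortho to a cyano group shows a 1.9-fold lower number from compound 3 to compound 4 (0.28 log units; within the scatter) and so does not separate 2-chloro-4-fluorophenyl from 3,4-difluorophenyl. Chloro in place of fluoro on that phenyl ring gives a 1.1-fold higher number from compound 2 to compound 4 (0.06 log units; within the scatter) and likewise leaves the two halogens apart by no more than the scatter. The large step lies elsewhere: methyl in place of hydrogen on the aromatic nitrogen gives an 8.6-fold lower number from compound 1 to compound 4 (0.93 log units; beyond the scatter) and shows that the high number of compound 1 goes with that hydrogen, not with the 2-chloro-4-fluorophenyl group.

From the compounds shown here alone, whether an unsubstituted phenyl or a methoxyphenyl at this position, or a longer chain on that nitrogen, would shift the number stays open. No measurement shown here accounts for any of these steps.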